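The compounds below may be only part of what the source reports. "The series", "measured", "known", "first", "only" and "open" are said of these compounds alone.

Of the compounds shown here, two have been measured so far in an ADME assay on a cell-free system (plasma, Rattus norvegicus, strain Sprague-Dawley) for metabolic stability, read by LC-MS; a lower number here means that the compound disappears faster, a higher number that the compound lasts longer. Compound 1 (`CC1=C(CC(=O)OCCOc2ccc3oc(=O)ccc3c2)c2cc(F)ccc2/C1=C\c1ccc([S+](C)[O-])cc1`) gives 0.0917 h, the higher of the two numbers, while compound 2 (`CC(C(=O)OCCOc1ccc2oc(=O)ccc2c1)c1ccc(-c2ccccc2)c(F)c1`) gives 0.0217 h, lower by more than the usual scatter. Compound 3 (`CC1=C(CC(=O)OCCOc2ccc3ccc(=O)oc3c2)c2cc(F)ccc2/C1=C\c1ccc([S+](C)[O-])cc1`) has the same atoms as compound 1, joined differently. The change is a group of 11 heavy atoms (9 carbon, 2 oxygen; one six-membered aromatic ring of carbon only, one six-membered aromatic ring with 1 hetero atom) in place of a group of 11 heavy atoms (9 carbon, 2 oxygen; one six-membered aromatic ring of carbon only, one six-membered aromatic ring with 1 hetero atom), on an oxygen on a saturated carbon, and the rest of the molecule stays as it is. The two groups match on everything counted, yet are connected differently. The comparison is a close one. Among the measured compounds shown here, no measured pair shows a change of this kind, so the expectation rests on that structural likeness alone. The estimated step of a 1.0-fold lower number from compound 1 to compound 3 (0.01 log units; within the scatter) is expected to stay within the scatter, with no clear direction. For compound 3, the expected half-life is 0.09 h, with an estimated range of 0.04 h to 0.2 h.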

Compound 3, half-life: 0.277 h
The estimate for compound 3 lay 3.1-fold (0.49 log units) below the measured number; the measured number lies above the stated range.
By their numbers in this assay, from the lowest: compound 2; then compound 1; then compound 3.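

In this assay, the two groups match on everything counted, including atoms, rings, hydrogen-bond acceptors and charge, yet the change gives a 3.0-fold higher number from compound 1 to compound 3 (0.48 log units; beyond the scatter) in this position, on an oxygen on a saturated carbon. This shows that how the group is connected can matter here, even when its counted make-up stays the same, something that compounds 1 and 2 alone could not show. Nothing measured here bears on why the number rises.

Among the compounds shown here, this change appears in only one pair, so it remains open whether the same rise would appear with the rest of compound 2 in place of the rest of compound 1. Also open, as far as these compounds go, is how the half-life would respond to a longer chain on that oxygen, or to an amine in place of either two-ring group.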